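Trimming the Amine of Compound 3

The compounds below may be only part of what the source reports. "The series", "measured", "known", "first", "only" and "open" are said of these compounds alone.

Of the compounds shown here, three built on one shared core have been tested in a functional assay on PC-3 cells (Homo sapiens), read by MTT assay, with a stated time of 48 h; a lower number here means a stronger inhibitor, a higher number a weaker inhibitor. Compound 1 `CCn1c(C(=O)NCCN(C)C)ccc1C(CC)(CC)c1ccc(OCC(=O)C(C)(C)C)c(C)c1` gives 2300 nM, compound 2 `CCN(CC)CCCNC(=O)c1ccc(C(CC)(CC)c2ccc(OCC(=O)C(C)(C)C)c(C)c2)n1CC` gives 1800 nM and compound 3 `CCn1c(C(=O)NCCN(C)C)ccc1C(CC)(CC)c1ccc(OCC(O)C(C)(C)C)c(C)c1` gives 1630 nM. Compound 3 stands level with the other two, as its gaps to both lie within the scatter of repeated measurements.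

Compound 4 `CCn1c(C(=O)NCCN)ccc1C(CC)(CC)c1ccc(OCC(O)C(C)(C)C)c(C)c1` has not yet been measured. It carries amino in place of dimethylamino on a saturated chain carbon, two bonds along the chain from an amide-type nitrogen.

The closest evidence is a change at that same place, where (diethylamino)methyl replaces dimethylamino: a 1.3-fold lower number from compound 1 to compound 2 (0.11 log units; within the scatter). The other measured step, a 1.4-fold lower number from compound 1 to compound 3 (0.15 log units; within the scatter), concerns a different place, with 1-hydroxy-2,2-dimethylpropyl in place of (tert-butyl)carbonyl, so it bears on this question only loosely. For the measured compounds named here, no tested compound carries a plain amino group here, which leaves the evidence indirect and the range wide.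

A step beyond the scatter in this assay is not expected in either direction. The expected step is a 1.0-fold higher number from compound 3 to compound 4 (0.02 log units; within the scatter). Compound 4 is estimated at 1700 nM, with an expected range from 750 nM to 3800 nM.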

Compound 4, half-maximal inhibitory concentration: 940 nM
Compound 4: the middle estimate sits 1.8-fold (0.26 log units) above what was measured; the measured number falls inside the stated range.
By their numbers in this assay, from the lowest: compounds 4, 3, 2 and 1 (each within the scatter of the next, the first and the last beyond it).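

Cutting dimethylamino down to amino takes this group from three heavy atoms to one and adds a hydrogen-bond donor, yet this assay shows only a 1.7-fold lower number from compound 3 to compound 4 (0.24 log units; within the scatter) for this change. The earlier evidence at this place came from a larger group, with (diethylamino)methyl giving a 1.3-fold lower number from compound 1 to compound 2 (0.11 log units; within the scatter) on the partner carrying (tert-butyl)carbonyl, so a step within the scatter has now been seen with both a larger and a smaller amine group on the chain, though on different partners. Nothing available on these compounds gives a measured reason for this result.

On these data alone, what remains open is whether the chain needs an amine at all, since a hydroxyl group or a carboxylic acid in place of amino could give a quite different number. Also open, as far as these compounds go, is how a longer chain, such as 3-aminopropyl in place of 2-aminoethyl, would read, and whether amino would give a similar step on the partner carrying (tert-butyl)carbonyl.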